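Swapping a Trihydroxyphenyl for Chlorophenyl on a Shared Core

A few compounds are considered here, and "the series" means these few. Any claim that something is new, unique, unknown or untested is made for them only; others in the source may bear on it.

Of the compounds shown here, two built on the same core have been tested in a functional assay on DU-145 cells (Homo sapiens) for inhibition, read by trypan blue exclusion, with a stated time of 96 h; a lower number here means a stronger inhibitor of growth, a higher number a weaker inhibitor of growth. Compound 1 `CCOc1ccc(/C=C(/Sc2ccccc2Cl)C(=O)c2ccc(Cl)cc2)cc1OC` gives 50000 nM in this assay. Compound 2 `Cc1ccc(CS/C(=C/c2ccc(O)c(O)c2O)C(=O)c2ccc(Cl)cc2)cc1` gives 50000 nM in this assay, which is level with compound 1 at the digits shown; the two are within the usual scatter of each other, so no order can be set between them.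

Compound 3 `Cc1ccc(CS/C(=C/c2ccc(Cl)cc2)C(=O)c2ccc(Cl)cc2)cc1` has not been measured. It differs from compound 2 in one place: 4-chlorophenyl in place of 2,3,4-trihydroxyphenyl on a double-bonded chain carbon bound to a double-bonded chain carbon.

Among the measured compounds shown here, with only two measured compounds, both weak and alike, no measured step is available to guide the change. The expectation is that the step from compound 2 to compound 3 stays within the scatter, with no clear direction, giving an estimated 1.3-fold lower number from compound 2 to compound 3 (0.10 log units; within the scatter) in this assay. Compound 3 is therefore estimated at 40000 nM in this assay, expected to fall between 10000 nM and 100000 nM.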

Compound 3, concentration for 50% growth inhibition: 10000 nM
Compound 3: middle estimate off by 4.0-fold (0.60 log units), on the high side, and the stated range covers the measured number.
By their numbers in this assay, from the lowest: compound 3; then compounds 1 and 2 (each within the scatter of the next).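

Replacing 2,3,4-trihydroxyphenyl with 4-chlorophenyl on a double-bonded chain carbon bound to a double-bonded chain carbon gives a 5.0-fold lower number from compound 2 to compound 3 (0.70 log units; beyond the scatter) in this assay and lies beyond the usual scatter, though it is modest. This shows that the group at this position can change the read-out, which the two earlier compounds, level with each other, could not show. The swap takes away all the hydrogen-bond donors and acceptors of the leaving group and brings in a chlorine in one step, and nothing available explains the shift.

Going by these compounds, it remains open whether a methoxy or an amine on this ring would give a number nearer compound 2 or compound 3. On these data alone, compound 3 gives 10000 nM in this read-out, and also open is whether a carboxylic acid or a longer chain here could give a still lower number.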